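The source may hold more compounds than are shown below. What is called first, only, known or untested is meant among the compounds shown, and "the series" means these compounds.

Measured compounds in this series:

Compound 1, `O=C(Nc1ccc(S(=O)(=O)N2CCC(O)CC2)cc1)c1ccc([N+](=O)[O-])o1` — > 25000 nM
Compound 2, `O=C(Nc1ccc(S(=O)(=O)N2CCC(Cl)CC2)cc1)c1ccc([N+](=O)[O-])o1` — > 25000 nM

In an ADME assay on IMR-90 cells (Homo sapiens) for cytotoxicity, read by CellTiter-Blue, with a stated time of 46 h (a lower number here means that less compound is needed, a higher number that more compound is needed for the effect), compound 1 gives only a limit of the assay, > 25000 nM. In this assay compound 2 likewise gives only a limit, > 25000 nM. The step that the two limits leave unreadable from compound 1 to compound 2 therefore cannot be read, and compound 2 stands at the limit rather than at a number; both values shown sit there, as stated in the limit of > 25000 nM in this assay, at which 2 of the 2 values shown sit.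

The next compound, compound 3, `N=C1CCN(S(=O)(=O)c2ccc(NC(=O)c3ccc([N+](=O)[O-])o3)cc2)CC1`, differs from compound 2 by 4-iminopiperidin-1-yl in place of 4-chloropiperidin-1-yl on a sulfonyl sulfur. Among the measured compounds shown here, no measured step touches the 4-iminopiperidin-1-yl group, and the only step that changes the same ring position, from compound 1 to compound 2, is itself unreadable. There is thus no measured basis for a step in either direction, and compound 3 is expected to remain where compound 2 stands, with the step of a number no higher from compound 2 to compound 3 (the limit leaves the size open) expected to be none beyond the scatter. Compound 3 is estimated at 25000 nM, with a range of 10000 nM to 60000 nM, most likely reported again only as a limit.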

Compound 3, half-maximal effective concentration: > 25000 nM
Compound 3 ended at the assay's limit; the forecaster's own chance of this, stated with the estimate: 85%; the middle value lies on the limit itself.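

In this assay compound 3 again gives only a limit, > 25000 nM. The steps linking compound 1, compound 2 and compound 3 therefore cannot be read: the limit of > 25000 nM in this assay, at which 3 of the 3 values shown sit.

The compounds shown leave open what concentration of any of them gives the effect, and whether the group on the sulfonyl sulfur changes it at all.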